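This account rests on a few compounds, and the source may have more. Where it says the series, first, only, none or still open, it means among the compounds named here.

Measured compounds in an ADME assay on PC-3 cells (Homo sapiens) for cytotoxicity, read by CCK-8 assay, with a stated time of 6 days; on this read-out lower numbers stand for stronger inhibition and higher numbers for weaker inhibition:

Compound 1 `CC(=O)c1ccc(C(=O)N[C@@H](C)Cn2ccc(-c3ccc(C#N)c(Cl)c3)n2)cc1`: in this assay compound 1 gives > 30000 nM, a limit of the assay and not a number.
Compound 2 `CC(Cn1ccc(-c2ccc(C#N)c(Cl)c2)n1)C(=O)Nc1cccc(C(C)O)c1`: in this assay compound 2 gives > 30000 nM, again a limit rather than a number.
Compound 3 `C[C@@H](Cn1ccc(-c2ccc(C#N)c(Cl)c2)n1)Nc1ccccc1`: in this assay compound 3 gives 3210 nM.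

Among the compounds with values here, compound 3 is thus the only member of the set with a number; the other two values sit at a limit, as noted in the limit of > 30000 nM in this assay, at which 2 of the 3 values shown sit. Within the data shown here, no pair of measured compounds differs in a single place, so no measured step is available, and where compound 3 stands relative to compounds 1 and 2 can only be said as: a number against two limits.

Compound 4 `C[C@@H](Cn1ccc(-c2ccc(C#N)c(Cl)c2)n1)Nc1ncnc2nc[nH]c12` has not been measured. It differs from compound 3 by a group of 9 heavy atoms (5 carbon, 4 nitrogen; one five-membered aromatic ring with 2 hetero atoms, one six-membered aromatic ring with 2 hetero atoms) in place of a group of 6 heavy atoms (6 carbon; one six-membered aromatic ring of carbon only), on an amine nitrogen; in words, a group of 9 heavy atoms (5 carbon, 4 nitrogen; one five-membered aromatic ring with 2 hetero atoms, one six-membered aromatic ring with 2 hetero atoms) in place of a group of 6 heavy atoms (6 carbon; one six-membered aromatic ring of carbon only), on an amine nitrogen. The amine nitrogen of compound 3 is kept, so compound 4 is expected to stay nearer compound 3 than the two limit compounds, with a step from compound 3 to compound 4 of a 1.6-fold higher number from compound 3 to compound 4 (0.19 log units; within the scatter) expected, at most a modest weakening and possibly none beyond the scatter. Compound 4 is estimated at 5000 nM in this assay, within 1500 nM to 20000 nM.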

Compound 4, half-maximal inhibitory concentration: 14100 nM
Beside the measured number, compound 4's estimate is 2.8-fold (0.45 log units) below it; the range from low to high includes it.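

Within the data shown here, on the amine nitrogen, in this assay, replacing phenyl with the group of 9 heavy atoms (one five-membered and one six-membered aromatic ring) gives a 4.4-fold higher number from compound 3 to compound 4 (0.64 log units; beyond the scatter), the first measured single-place step. This position therefore responds to the group it carries, yet with this change compound 4 still gives a number, 14100 nM. Compound 1 and compound 2 remain at a limit of the assay and not a number: the limit of > 30000 nM in this assay, at which 2 of the 4 values shown sit.

A single step cannot separate the contribution of the second ring from that of the ring nitrogens or the added hydrogen-bond donor and acceptors. Going by these compounds, a pyridyl or benzyl group on the same amine nitrogen would help to separate these, and the effect of any change elsewhere on the shared core remains open.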